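This account rests on a few compounds, and the source may have more. Where it says the series, first, only, none or still open, it means among the compounds named here.

Within an assay on isolated protein with malate dehydrogenase, mitochondrial (Sus scrofa) as the target (on this read-out lower numbers stand for stronger inhibition and higher numbers for weaker inhibition), compound 1, with the structure `CN(C)c1ccc2c(O)c(C(=O)O)cnc2c1`, holds the higher of the two numbers recorded so far: in this assay compound 1 gives 479000 nM. Going by the values given here, the only other measured compound, compound 2, with the structure `O=C(O)c1cnc2cc(OCCc3ccc(Br)cc3)ccc2c1O`, gives in this assay 2510 nM, so the two values stand far apart, well beyond the usual scatter, and no single-point step links them.

Compound 3, with the structure `O=C(O)c1cnc2cc(F)ccc2c1O`, differs from compound 1 in one place: fluoro in place of dimethylamino on an aromatic carbon. The change replaces the dimethylamino group with fluoro on an aromatic carbon of the six-membered carbon-only ring of the fused two-ring core, the position described as meta to a fused ring and para to a fused ring.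

Among the compounds with values here, no measured pair shows this kind of exchange, so the size of the step is a guess. Given that compound 1 already gives 479000 nM, a weak result, the expectation is that compound 3 stays in the same weak region, with a step from compound 1 to compound 3 of a 1.4-fold lower number from compound 1 to compound 3 (0.14 log units; within the scatter), not clearly beyond the scatter. Compound 3 is therefore estimated at 350000 nM, with a range from 70000 nM to 1500000 nM.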

Compound 3, half-maximal inhibitory concentration: 10500000 nM
For compound 3 the middle estimate is 30-fold (1.48 log units) below the measured one; measured number outside the range, above it.
By their numbers in this assay, from the lowest: compound 2; then compound 1; then compound 3.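

In this assay, the aromatic carbon that is meta to a fused ring and para to a fused ring proves sensitive to what it carries: fluoro in place of dimethylamino gives a 22-fold higher number from compound 1 to compound 3 (1.34 log units; beyond the scatter), a large step towards weaker inhibition. The earlier compounds shown here could not show this, as no single-place change linked them, and this pair also shows that the already weak compound 1 does not mark the weak end of the series. The exchange removes three heavy atoms and a hydrogen-bond acceptor and introduces a single fluorine, but nothing available explains the step or ties it to either of these differences.

This one pair leaves open whether an amine such as amino or diethylamino, or a group such as methoxy or chloro, on this same carbon would fall nearer compound 1 or nearer compound 3. It also leaves open whether the exchange of dimethylamino for fluoro would produce a step of similar size on a core that carries a longer chain elsewhere.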